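Chloro in place of dimethylamino: where compound 3 may land

This account rests on a few compounds, and the source may have more. Where it says the series, first, only, none or still open, it means among the compounds named here.

Within the data shown here, in a functional assay on UACC-62 cells (Homo sapiens) for cytotoxicity, read by sulforhodamine B assay (a higher number here means a weaker inhibitor of growth, a lower number a stronger inhibitor of growth), compound 1 (`CC1=CC[C@@H]([C@@](C)(O)CCCC(C)(C)NC=S)CC1`) gives 9960 nM as the only actual number so far. Compound 2 (`CC1=CC[C@@H]([C@@](C)(O)CCCC(C)(C)NC(=S)N/N=C\c2ccc(N(C)C)cc2)CC1`) reads > 100000 nM in this assay and this is a limit of the assay, not a number. Among the measured compounds shown here, compound 2 thus stands on the limit of > 100000 nM in this assay, at which 1 of the 2 values shown sits, and offers no measured step to work from.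

Compound 3 (`CC1=CC[C@@H]([C@@](C)(O)CCCC(C)(C)NC(=S)N/N=C\c2ccc(Cl)cc2)CC1`) differs from compound 2 in one place: chloro in place of dimethylamino on an aromatic carbon and the change is chloro in place of dimethylamino on an aromatic carbon, para to a large group. For the measured compounds named here, no measured pair shows what this change does. Going by the values given here, with compound 1 at 9960 nM as the only number available, a modest move toward stronger inhibition of growth is expected. A second reading at the limit remains possible. The expected change is an at least 2.8-fold lower number from compound 2 to compound 3 (0.45 log units; beyond the scatter) in this assay and its size is only a rough estimate. Compound 3 is expected at 35000 nM in this assay with an estimated range from 10000 nM to 100000 nM as its span.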

Compound 3, concentration for 50% growth inhibition: 7350 nM
Beside the measured number, compound 3's estimate is 4.8-fold (0.68 log units) above it; the measured number lies below the stated range.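

At this position, on an aromatic carbon para to a large group, the series now has its first measured outcome for a single change in this assay: chloro in place of dimethylamino gives an at least 13-fold lower number from compound 2 to compound 3 (1.13 log units; beyond the scatter). The substituent at this one place is therefore enough to separate a reading at the limit from a measurable number, with the rest of the structure held constant. The true size of the step remains unknown, and the printed figure is only a lower bound, because compound 2 reads as a limit of the assay and not as a number: the limit of > 100000 nM in this assay, at which 1 of the 3 values shown sits.

A single pair cannot separate the effect of losing dimethylamino from that of gaining chloro, and a methoxy group, a fluoro group or a plain hydrogen on the same aromatic carbon would help to tell these two apart. Also open, going by these compounds, is whether the trend extends to other types of group at this place, such as a carboxylic acid or a primary amine, and whether chloro on a different carbon of the same aromatic ring would give a similar number.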